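A few compounds are considered here, and "the series" means these few. Any claim that something is new, unique, unknown or untested is made for them only; others in the source may bear on it.

Three related compounds have been tested in a functional assay on MDA-MB-231 cells (Homo sapiens) for cytotoxicity, read by MTT assay, with a stated time of 72 h; a higher number here means a weaker inhibitor, a lower number a stronger inhibitor. Compound 1, `CN(C)CCCNc1nc(-c2ccc(NC(=O)Nc3ccccc3F)cc2)nc2ccsc12`, gives 660 nM. Compound 3, `CN(C)CCNc1nc(-c2ccc(NC(=O)Nc3ccccc3F)cc2)nc2ccsc12`, gives 600 nM. Compound 2, `CN(C)CCCNc1nc(-c2ccc(NC(=O)Nc3ccc(F)cc3)cc2)nc2c(Cl)c(Cl)sc12`, gives 980 nM. The gap between compound 2 and each of the other two is within the scatter of the measurement, so no order among the three can be read from these numbers.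

Compound 1 and compound 3 differ in one place only: dimethylamino in place of (dimethylamino)methyl on a saturated chain carbon, two bonds along the chain from a nitrogen on an aromatic ring. This change gives a 1.1-fold lower number from compound 1 to compound 3 (0.04 log units; within the scatter), a step that sits within the scatter, so the shorter chain is not seen to alter the result here.

Compound 2 and compound 4 differ by the same change: dimethylamino in place of (dimethylamino)methyl on a saturated chain carbon, two bonds along the chain from a nitrogen on an aromatic ring. Compound 4, `CN(C)CCNc1nc(-c2ccc(NC(=O)Nc3ccc(F)cc3)cc2)nc2c(Cl)c(Cl)sc12`, has not yet been measured in this assay. The difference between the core of compound 2 and the core of compound 1 is not broken down here; the two share the chain and the same kind of side group, and both carry the change to the shorter chain in the same place.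

Within the data shown here, with only one measured example of this change to lean on, the step from compound 2 to compound 4 is expected to be small, estimated as a 1.1-fold lower number from compound 2 to compound 4 (0.04 log units; within the scatter), because the same change between compound 1 and compound 3 gave a 1.1-fold lower number from compound 1 to compound 3 (0.04 log units; within the scatter). Compound 4 is therefore expected to give about 900 nM in this assay, most likely somewhere between 450 nM and 1800 nM.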

Compound 4, half-maximal inhibitory concentration: 1240 nM
Compound 4: middle estimate off by 1.4-fold (0.14 log units), on the low side, and the stated range covers the measured number.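

In this assay, swapping the 3-(dimethylamino)propyl chain of compound 2 for the 2-(dimethylamino)ethyl chain gives a 1.3-fold higher number from compound 2 to compound 4 (0.10 log units; within the scatter), so this step, like the earlier one, stays inside the usual spread of repeat measurements. Set side by side, the two steps cannot be told apart, so the change behaves alike on both cores as far as this measurement can tell: the same change on two cores in this assay, a 1.1-fold lower number (0.04 log units; within the scatter) from compound 1 to compound 3 and a 1.3-fold higher number (0.10 log units; within the scatter) from compound 2 to compound 4, 1.4-fold (0.14 log units) apart, within the scatter of two such steps

This shows that, in these two pairs, the shorter chain leaves no visible mark on the number, and that the small step seen on the core of compound 1 was a fair guide to the small step on the core of compound 2, but it does not show that the chain length is without any effect, since a small real effect could hide inside the scatter, and two pairs cannot set a rule for other cores or other assays.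

The compounds shown leave open what a longer chain, such as 4-(dimethylamino)butyl, or a different amine at the chain end, such as pyrrolidine or morpholine, would do in this assay. Going by these compounds, the effect of the difference between the two cores alone also stays open, with compound 1 and compound 2 differing in more than one place.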